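Moving Methyl Groups on the Benzyl Arm

The source may hold more compounds than are shown below. What is called first, only, known or untested is meant among the compounds shown, and "the series" means these compounds.

Compound 1 `Cc1cc(C)cc(Cn2c(=O)ccn(C3C=CC(OC(=O)c4ccccc4)C3)c2=O)c1` was tested in an ADME assay on CCRF-CEM cells (Homo sapiens) for cytotoxicity, with a stated time of 3 days (a lower number here means that less compound is tolerated, a higher number that more compound is tolerated), where compound 1 gives 40000 nM. Compound 1 stands with the higher of the two plain numbers shown, but the gap to its nearest neighbour lies within the scatter. Compound 3 `Cc1ccc(Cn2c(=O)ccn(C3C=CC(OC(=O)c4ccccc4)C3)c2=O)c(C)c1` gives 31000 nM in this assay. Compound 2 `Cc1cc(=O)[nH]c(=O)n1C1C=CC(OC(=O)c2ccccc2)C1`, which carries no benzyl arm, reaches only a limit of this assay, > 250000 nM, and no number. For the measured compounds named here, the single step between measured compounds differing in one place, a 1.3-fold lower number from compound 1 to compound 3 (0.11 log units; within the scatter), is within the scatter.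

The step followed here leads to compound 4 `Cc1ccc(Cn2c(=O)ccn(C3C=CC(OC(=O)c4ccccc4)C3)c2=O)cc1`, which differs from compound 1 by 4-methylphenyl in place of 3,5-dimethylphenyl on a saturated chain carbon bound to an aromatic nitrogen. Going by the values given here, only the step from compound 1 to compound 3 bears on this change, as it also rearranges the methyl groups of the phenyl on the saturated chain carbon bound to an aromatic nitrogen, and that step stayed within the scatter. In this assay no step beyond the scatter is therefore expected. Compound 4 is expected to give 40000 nM, with a range from 15000 nM to 110000 nM, which means an expected step of no change at the digits printed from compound 1 to compound 4 (within the scatter).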

Compound 4, half-maximal cytotoxic concentration: > 25000 nM
Compound 4: a limit, no number (the forecaster's own chance of this, stated with the estimate: 10%); the middle value does not contradict the limit.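

In this assay compound 4 gives > 25000 nM as a limit and not a number. Its steps from compound 1 and from compound 3 therefore cannot be read. The compounds shown leave open whether the 4-methylbenzyl arm of compound 4 is tolerated differently from the 3,5-dimethylbenzyl arm of compound 1.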